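This account rests on a few compounds, and the source may have more. Where it says the series, first, only, none or still open, it means among the compounds named here.

Measured so far:
compound 1 `CCSS/C(CCOC(=O)[C@@H](C)c1ccc2cc(OC)ccc2c1)=C(/C)N(C=O)CC(=O)OC[C@H]1O[C@H](O)[C@H](O)[C@@H](O)[C@@H]1O` gives 16 h in a physicochemical assay for pharmacokinetics, read by HPLC, in phosphate buffer, at pH 2.5; a lower number here means that the compound disappears faster, a higher number that the compound lasts longer
compound 2 `COc1ccc2cc([C@H](C)C(=O)OCC/C(SSC(C)C)=C(\C)N(C=O)CC(=O)OC[C@H]3O[C@H](O)[C@H](O)[C@@H](O)[C@@H]3O)ccc2c1` gives 21.7 h in this assay

Compound 2 has the nearest neighbour in compound 1, and the step of a 1.4-fold higher number from compound 1 to compound 2 (0.13 log units; within the scatter) lies within the scatter, so the two stand level in this assay. Compound 3 `COc1ccc2cc([C@H](C)C(=O)OCC/C(SSCc3ccccc3)=C(\C)N(C=O)CC(=O)OC[C@H]3O[C@H](O)[C@H](O)[C@@H](O)[C@@H]3O)ccc2c1` differs from compound 2 by benzyl in place of isopropyl on a sulfur. Within the data shown here, the one measured step, a 1.4-fold higher number from compound 1 to compound 2 (0.13 log units; within the scatter), touches another place and was within the scatter; no step at the sulfur carrying the exchanged group has been measured. For compound 3 no change beyond the scatter is therefore expected, a 1.1-fold lower number from compound 2 to compound 3 (0.04 log units; within the scatter). Compound 3 is estimated at 20 h, range 10 h to 40 h.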

Compound 3, half-life: 20.4 h
Estimate against measurement, compound 3: 1.0-fold (0.01 log units) below; the measured number falls inside the stated range.
By their numbers in this assay, from the lowest: compounds 1, 3 and 2 (each within the scatter of the next).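

On a sulfur, benzyl in place of isopropyl gives a 1.1-fold lower number from compound 2 to compound 3 (0.03 log units; within the scatter) in this assay, so this first step read at that sulfur shows no shift despite the added aromatic ring. Phenyl in place of methyl on a saturated chain carbon bound to a sulfur gives a 1.3-fold higher number from compound 1 to compound 3 (0.11 log units; within the scatter) as well, and compound 1, compound 2 and compound 3 stand level across the three groups on the sulfur. Nothing at hand gives a reason for this level reading.

From the compounds shown here alone, whether an amine or a carboxylic acid on that sulfur would move the half-life beyond the scatter stays open. So does the reading of these compounds at another pH.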